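Heteroaryl exchange on the methylene in the shared core

This account rests on a few compounds, and the source may have more. Where it says the series, first, only, none or still open, it means among the compounds named here.

Measured so far:
Compound 1, `CCc1nc(C)c(CN2CCN(c3cccc4[nH]c(-c5ccc(C(C)(C)C)cc5)nc34)CC2)o1`, in an assay on isolated protein for displacement of a labelled ligand from Gonadotropin-releasing hormone receptor (Homo sapiens) (a higher number here means a weaker inhibitor, a lower number a stronger inhibitor), compound 1 gives 37 nM.
Compound 2, `CCc1cc(CN2CCN(c3cccc4[nH]c(-c5ccc(C(C)(C)C)cc5)nc34)CC2)nn1C`, in this assay compound 2 gives 43 nM.

Compound 2 carries the higher of the two numbers, but the gap to compound 1 is small: a 1.2-fold higher number from compound 1 to compound 2 (0.07 log units; within the scatter). Those two values are not distinguishable.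

Compound 3, `CCCn1cnc(CN2CCN(c3cccc4[nH]c(-c5ccc(C(C)(C)C)cc5)nc34)CC2)c1C`, is the next step from compound 2. The change is 5-methyl-1-propyl-1H-imidazol-4-yl in place of 5-ethyl-1-methyl-1H-pyrazol-3-yl on a saturated chain carbon bound to an amine nitrogen in a ring. Going by the values given here, the only step that bears on it is the earlier exchange of one five-membered aromatic ring with two hetero atoms for another at the same place, a 1.2-fold higher number from compound 1 to compound 2 (0.07 log units; within the scatter), which stayed within the scatter. A second exchange of this kind, again keeping two hydrogen-bond acceptors and no donor, is therefore expected to move the number little: a 1.0-fold higher number from compound 2 to compound 3 (0.02 log units; within the scatter). Compound 3 is estimated at 45 nM in this assay, with a range from 20 nM to 100 nM.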

Compound 3, half-maximal inhibitory concentration: 12 nM
The estimate for compound 3 lay 3.8-fold (0.57 log units) above the measured number; the whole stated range lies above it.
By their numbers in this assay, from the lowest: compound 3; then compounds 1 and 2 (each within the scatter of the next).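

This position, the saturated chain carbon bound to an amine nitrogen in a ring, is sensitive to which heteroaryl group it carries. In this assay the exchange gives a step beyond the scatter (a 3.6-fold lower number from compound 2 to compound 3 (0.55 log units; beyond the scatter)) and a similar one against the oxazole (a 3.1-fold lower number from compound 1 to compound 3 (0.49 log units; beyond the scatter)), while the earlier exchange stayed within it (a 1.2-fold higher number from compound 1 to compound 2 (0.07 log units; within the scatter)). Matching ring size, hetero atom count and donor and acceptor counts therefore does not fix the number, and nothing measured here accounts for the difference.

The compounds shown do not separate the imidazole ring itself from its 1-propyl and 5-methyl groups, which enter together. A 1-methyl imidazole, a longer chain such as 1-butyl, or a propyl chain ending in an amine would show how much of the step follows that chain.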